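Phenyl Urea Variant of a Frizzled-Related Protein Ligand

This account rests on a few compounds, and the source may have more. Where it says the series, first, only, none or still open, it means among the compounds named here.

Compound 1 `CC(C)(C)CC(=O)N1CCC[C@H]1C(=O)N1CCC(NS(=O)(=O)c2cc(S(=O)(=O)c3ccccc3)ccc2C(F)(F)F)CC1` and compound 2 `CCNC(=O)N1CCC[C@H]1C(=O)N1CCC(NS(=O)(=O)c2cc(S(=O)(=O)c3ccccc3)ccc2C(F)(F)F)CC1` share one core and differ only in the group on the carbonyl carbon that caps the proline-like ring. In an assay on isolated protein for binding affinity to secreted frizzled-related protein 1 (Homo sapiens), read by fluorescence (on this read-out lower numbers stand for stronger inhibition and higher numbers for weaker inhibition), compound 1 gives 20 nM, and compound 2 gives 30 nM. The step of a 1.5-fold higher number from compound 1 to compound 2 (0.18 log units; within the scatter) shows that this exchange changed little. Compound 2 thus holds the higher of the two numbers, yet its distance to compound 1 falls inside the scatter, so the two count as equal.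

Compound 3 `O=C([C@@H]1CCCN1C(=O)Nc1ccccc1)N1CCC(NS(=O)(=O)c2cc(S(=O)(=O)c3ccccc3)ccc2C(F)(F)F)CC1` takes the next step at the same end of the molecule: phenyl in place of ethyl on an amide-type nitrogen. Among the measured compounds shown here, only one measured step touches this position, namely a 1.5-fold higher number from compound 1 to compound 2 (0.18 log units; within the scatter), and it was small. Nothing measured tells how an aromatic ring behaves there, so the expectation rests on that single small step. The estimated change from compound 2, no change at the digits printed from compound 2 to compound 3 (within the scatter), stays within the scatter. Compound 3 is therefore expected to give about 30 nM in this assay, with a likely range from 10 nM to 90 nM.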

Compound 3, half-maximal inhibitory concentration: 20 nM
Compound 3: middle estimate off by 1.5-fold (0.18 log units), on the high side, and the stated range covers the measured number.
By their numbers in this assay, from the lowest: compounds 1, 3 and 2 (each within the scatter of the next).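

In this assay, the exchange of ethyl for phenyl on the amide-type nitrogen gives a 1.5-fold lower number from compound 2 to compound 3 (0.18 log units; within the scatter) and the exchange of neopentyl for anilino on the carbonyl carbon gives no change at the digits printed from compound 1 to compound 3 (within the scatter) on the same read-out. Among the compounds shown here, this is the first measurement of an aromatic ring at this end of the molecule, and since both steps lie within the scatter, compounds 1, 2 and 3 cannot be told apart, even though the entering phenyl brings a six-membered aromatic ring where ethyl had none. No independent measurement is available to explain why these three groups read alike.

The compounds shown leave open how a phenyl ring carrying a further group, such as chlorophenyl or methoxyphenyl, or a ring containing nitrogen, such as pyridyl, would read on this amide-type nitrogen. They also leave open whether this end of the molecule would accept a carboxylic acid or an amine at the end of a longer chain, so the level shared by these three compounds cannot yet be extended beyond them.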